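Fluoro for methoxy on a low-toxicity compound

A few compounds are considered here, and "the series" means these few. Any claim that something is new, unique, unknown or untested is made for them only; others in the source may bear on it.

Measured in an ADME assay on MT4 cells (Homo sapiens) for cytotoxicity, read by MTT assay, with a stated time of 4 days; on this read-out lower numbers stand for higher toxicity in this test and higher numbers for lower toxicity in this test:
compound 1 `CC(=O)Nc1ccc(O)c(C(=O)/C=C/c2ccccc2)c1`: 49400 nM
compound 2 `COc1cccc(-c2cc(=O)c3cc(NC(C)=O)ccc3o2)c1`: > 404000 nM (a limit, not a number)

Compound 2 stands at the limit of > 404000 nM in this assay, at which 1 of the 2 values shown sits. Compound 3 `CC(=O)Nc1ccc2oc(-c3cccc(F)c3)cc(=O)c2c1` has fluoro in place of methoxy on an aromatic carbon. Within the data shown here, no measured pair shows this change, so the expectation rests on compound 2 at the limit of > 404000 nM in this assay, at which 1 of the 2 values shown sits. In this assay the expected step is a number no higher from compound 2 to compound 3 (the limit leaves the size open), with no change beyond the scatter and a good chance of another limit. The estimated value for compound 3 is 400000 nM, with an expected range of 150000 nM to 450000 nM.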

Compound 3, half-maximal cytotoxic concentration: 240000 nM
Beside the measured number, compound 3's estimate is 1.7-fold (0.22 log units) above it, within the range that was stated.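

In this assay, fluoro in place of methoxy on an aromatic carbon comes with an at least 1.6-fold lower number from compound 2 to compound 3 (0.22 log units; that floor lies within the scatter). Compound 3 gives 240000 nM, so this position of the series now carries a measured number. The true size of the step stays open because compound 2 is held at a limit: the limit of > 404000 nM in this assay, at which 1 of the 3 values shown sits.

As far as these compounds go, whether an amine or a carboxylic acid at the same place would keep the number in this region remains open. So does whether the change from methoxy to fluoro moves the number beyond the scatter at all.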